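A few compounds are considered here, and "the series" means these few. Any claim that something is new, unique, unknown or untested is made for them only; others in the source may bear on it.

Within the data shown here, compound 3 `CCc1nc(-c2ccc(Cl)cc2Cl)c(CC)nc1NC(C)CN(C)C` gives 489 nM in an assay on IMR-32 cells for displacement of a labelled ligand from corticotropin-releasing factor receptor 1 (Homo sapiens), read by scintillation counting, with a stated time of 2 h (a higher number here means a weaker inhibitor, a lower number a stronger inhibitor), and stands second highest of the three numbers measured so far. Its nearest neighbour is compound 1 `CCc1nc(NC(CC)CC)cnc1-c1ccc(Cl)cc1Cl`, whose 545 nM in this assay lies within the scatter of it, and the furthest is compound 2 `CCc1nc(N(CC2CC2)CC2CC2)c(CC)nc1-c1ccc(Cl)cc1Cl`, which in this assay gives 26 nM. Among the measured compounds shown here, the only single-site step measured is a 19-fold higher number from compound 2 to compound 3 (1.27 log units; beyond the scatter), showing that exchange of the amino substituent on the shared core can move the number a great deal. Compound 4 `CCc1nc(-c2ccc(Cl)cc2Cl)c(CC)nc1NC(CC)CC` differs from compound 3 by pentan-3-yl in place of 1-((dimethylamino)methyl)ethyl on a nitrogen on an aromatic ring. For the measured compounds named here, no measured step covers this exact exchange. Compound 1 carries the same pentan-3-ylamino group on a core with one ethyl fewer and gives a number within the scatter of compound 3, while compound 2, with a different amino substituent on the same diethyl core, sits far lower. A moderate fall is therefore expected, a 3.3-fold lower number from compound 3 to compound 4 (0.51 log units; beyond the scatter), though the size is uncertain. Compound 4 is expected to give 150 nM in this assay, with a range from 40 nM to 600 nM.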

Compound 4, inhibition constant: 4.1 nM
Beside the measured number, compound 4's estimate is 37-fold (1.56 log units) above it; the measured number lies below the stated range.
By their numbers in this assay, from the lowest: compound 4; then compound 2; then compounds 3 and 1 (each within the scatter of the next).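

On the shared core, the amino substituent counts for more than compound 3 alone suggested: in this assay, pentan-3-yl in place of 1-((dimethylamino)methyl)ethyl on the nitrogen gives a 120-fold lower number from compound 3 to compound 4 (2.08 log units; beyond the scatter) and makes compound 4 the strongest inhibitor of the four. The same (pentan-3-yl)amino group also outdoes bis(cyclopropylmethyl)amino, with a 6.3-fold lower number from compound 2 to compound 4 (0.80 log units; beyond the scatter) as a modest step. This group does not set the number alone, since ethyl in place of hydrogen on an aromatic carbon gives a 130-fold lower number from compound 1 to compound 4 (2.12 log units; beyond the scatter) and the closeness of compound 1 to compound 3 therefore says little about the substituent on the nitrogen.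

No evidence here explains any of these steps. Open, on these data alone, is whether a longer chain on that nitrogen, or a methyl or propyl group in place of that ethyl, would hold the number this low.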